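The source may hold more compounds than are shown below. What is called first, only, known or untested is meant among the compounds shown, and "the series" means these compounds.

Compound 3 `Cc1ccccc1-n1nc(C)c2c1NC(=O)[C@H](C)S[C@@H]2c1ccc(Oc2ccccc2)cc1` carries a phenoxy group at the end of the shared core, and in an assay on isolated protein for agonist activity at Bile acid receptor (Homo sapiens), read by AlphaScreen, with a stated time of 30 min (on this read-out higher numbers stand for an effect only at larger amounts of compound and lower numbers for an effect already at smaller amounts), compound 3 gives 1300 nM. Among the three measured compounds this is the lowest number, though compound 1 `Cc1ccccc1-n1nc(C)c2c1NC(=O)[C@H](C)S[C@@H]2c1ccc(-c2ccsc2)cc1`, with thiophen-3-yl in that position, gives 1400 nM, and the two lie within the scatter (a 1.1-fold lower number from compound 1 to compound 3 (0.03 log units; within the scatter)). Compound 2 `CCOc1cccc(-c2ccc([C@H]3S[C@@H](C)C(=O)Nc4c3c(C)nn4-c3ccccc3C)cc2)c1`, with 3-ethoxyphenyl, gives 3500 nM, and the step of a 2.7-fold lower number from compound 2 to compound 3 (0.43 log units; beyond the scatter) is modest but beyond the scatter, as is a 2.5-fold higher number from compound 1 to compound 2 (0.40 log units; beyond the scatter).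

Compound 4 `COc1ccccc1Oc1ccc([C@H]2S[C@@H](C)C(=O)Nc3c2c(C)nn3-c2ccccc2C)cc1` differs from compound 3 by a single change: methoxy in place of hydrogen on an aromatic carbon, sitting ortho to a large group. Among the measured compounds shown here, none of the measured steps adds a substituent to the distal ring; each swaps the whole group, and the three numbers together span only a modest range. Nothing measured therefore points to a large movement in either direction. Compound 4 is thus expected to sit close to compound 3, with an estimated step of no change at the digits printed from compound 3 to compound 4 (within the scatter). The estimate for compound 4 is 1300 nM, with a range from 450 nM to 3800 nM.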

Compound 4, half-maximal effective concentration: 1700 nM
Compound 4: the middle estimate sits 1.3-fold (0.12 log units) below what was measured, within the range that was stated.
By their numbers in this assay, from the lowest: compounds 3, 1 and 4 (each within the scatter of the next); then compound 2.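

The phenoxy group of compound 3 takes a methoxy ortho to a large group with no reading beyond the scatter in this assay (a 1.3-fold higher number from compound 3 to compound 4 (0.12 log units; within the scatter)), the first step shown that adds to this group rather than replacing it whole. The 2-methoxyphenoxy group also stays within the scatter of thiophen-3-yl (a 1.2-fold higher number from compound 1 to compound 4 (0.08 log units; within the scatter)), while the step against 3-ethoxyphenyl remains modest but beyond the scatter (a 2.1-fold lower number from compound 2 to compound 4 (0.31 log units; beyond the scatter)). No evidence is available to explain why this added methoxy leaves the number within the scatter.

From the compounds shown here alone, whether an amine, a carboxylic acid or a longer chain in place of the methoxy would move the number beyond the scatter stays open. Also open, going by these compounds, is whether a methoxy would be tolerated in the same way on the 3-ethoxyphenyl group of compound 2 or the thiophen-3-yl group of compound 1.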